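Working notes: the step from compound 2 to compound 4

A few compounds are considered here, and "the series" means these few. Any claim that something is new, unique, unknown or untested is made for them only; others in the source may bear on it.

Three compounds have numbers in an ADME assay on RAW264.7 cells (Mus musculus) for cytotoxicity, read by MTT assay, with a stated time of 72 h, tested at 50 uM; a lower number here means less inhibition, a higher number more inhibition at the concentration tested (going by the name of the read-out):

compound 1 `CCOC(=O)c1sc(-c2ccccc2)nc1N1CCC(NCc2ccc(F)cc2)CC1` gives 6.23%
compound 2 `CCOC(=O)c1sc(-c2ccncc2)nc1N1CCC(NCc2ccc(F)cc2)CC1` gives 17.5%
compound 3 `CCOC(=O)c1sc(-c2ccncc2)nc1N1CCC(NCc2ccc(OCc3ccccc3)cc2)CC1` gives 8.04%

Compound 2 holds the highest of the three numbers in this assay. Compound 3 lies nearest to it, a number 9.5 percentage points lower from compound 2 to compound 3 (within the scatter), and compound 1 furthest, a number 11.3 percentage points higher from compound 1 to compound 2 (beyond the scatter).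

Compound 4 `CCOC(=O)c1sc(-c2ccncc2)nc1N1CCC(NCc2cccc(C(F)(F)F)c2)CC1` is not yet measured in this assay. It differs from compound 2 in one place: 3-(trifluoromethyl)phenyl in place of 4-fluorophenyl on a saturated chain carbon bound to an amine nitrogen. Within the data shown here, no measured step changes the group at this place in the same way. Among the measured compounds shown here, the nearest comparison is the change at the same place in compound 3, where a number 9.5 percentage points lower from compound 2 to compound 3 (within the scatter); the only step beyond the scatter, a number 11.3 percentage points higher from compound 1 to compound 2 (beyond the scatter), concerns a different place in the molecule. With one change at this place within the scatter and nothing else to go on, the expected step in this assay is a number 2.5 percentage points lower from compound 2 to compound 4 (within the scatter), not beyond the scatter. Compound 4 is therefore estimated at 15%, with a range from 3% to 30%.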

Compound 4, a percentage reported as inhibition, at one concentration (the size of the read-out at that concentration, not a potency): 14.3%
Compound 4: middle estimate off by 0.7 percentage points, on the high side, within the range that was stated.
By their numbers in this assay, from the lowest: compounds 1, 3, 4 and 2 (each within the scatter of the next, the first and the last beyond it).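

In this assay, among these compounds, the exchange of 4-fluorobenzyl for 3-(trifluoromethyl)benzyl gives a number 3.2 percentage points lower from compound 2 to compound 4 (within the scatter) and so adds a second change at this place that stays within the scatter, after the one that gave a number 9.5 percentage points lower from compound 2 to compound 3 (within the scatter) at the same place. The entering group has 10 heavy atoms against 7 for the group that leaves, and among compound 2, compound 3 and compound 4 no change at this place has yet produced a step beyond the scatter. Nothing available gives a reason for the size of this step.

The compounds shown leave open whether an amine, a carboxylic acid or a longer chain on the benzyl group would give a step beyond the scatter. They also leave open whether the pyridin-4-yl change that gave a number 11.3 percentage points higher from compound 1 to compound 2 (beyond the scatter) with 4-fluorobenzyl holds with 3-(trifluoromethyl)benzyl.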